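Swapping 2-hydroxyphenyl for 2,4-dichlorophenyl

The source may hold more compounds than are shown below. What is called first, only, known or untested is meant among the compounds shown, and "the series" means these compounds.

In a functional assay on MCF7 cells (Homo sapiens) for cytotoxicity, read by MTT assay, with a stated time of 48 h (a lower number here means a stronger inhibitor, a higher number a weaker inhibitor), three compounds sharing one core have been measured. Compound 1 (`O=C(CSc1nnc(-c2ccncc2)o1)N/N=C/c1ccccc1`) stands at 14600 nM and compound 2 (`O=C(CSc1nnc(-c2ccncc2)o1)N/N=C/c1ccccc1[N+](=O)[O-]`) at 35600 nM on this scale. Compound 3 (`O=C(CSc1nnc(-c2ccncc2)o1)N/N=C/c1ccccc1O`) gives 4750 nM and so has the lowest number of the three, which makes it the strongest inhibitor so far.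

Compound 4 (`O=C(CSc1nnc(-c2ccncc2)o1)N/N=C/c1ccc(Cl)cc1Cl`) has 2,4-dichlorophenyl in place of 2-hydroxyphenyl on a carbon with a double bond to nitrogen. Hydroxy in place of hydrogen gave a 3.1-fold lower number from compound 1 to compound 3 (0.49 log units; beyond the scatter) so losing that hydroxy could undo a step of similar size. Nitro in place of hydrogen gave a 2.4-fold higher number from compound 1 to compound 2 (0.39 log units; beyond the scatter) and hydroxy in place of nitro gave a 7.5-fold lower number from compound 2 to compound 3 (0.87 log units; beyond the scatter) so each swap among these three compounds has moved the number beyond the scatter. Within the data shown here, no measured compound carries chlorine, so these steps guide the expectation only loosely.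

The expected move (a 2.5-fold higher number from compound 3 to compound 4 (0.40 log units; beyond the scatter)) is modest and toward a higher number. Compound 4 is expected to give 12000 nM and the range from 4000 nM to 35000 nM is the estimated likely span.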

Compound 4, half-maximal inhibitory concentration: 27900 nM
For compound 4 the middle estimate is 2.3-fold (0.37 log units) below the measured one; the measured number falls inside the stated range.
By their numbers in this assay, from the lowest: compound 3; then compounds 1, 4 and 2 (each within the scatter of the next, the first and the last beyond it).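

The gain from 2-hydroxyphenyl on this carbon does not carry over to 2,4-dichlorophenyl: in this assay the swap gives a 5.9-fold higher number from compound 3 to compound 4 (0.77 log units; beyond the scatter) and leaves compound 3 as the strongest of the four, with its steps to all the others beyond the scatter. The dichloro compound cannot be separated from either of the other two, with a 1.9-fold higher number from compound 1 to compound 4 (0.28 log units; within the scatter) and a 1.3-fold lower number from compound 2 to compound 4 (0.11 log units; within the scatter), even though compound 1 and compound 2 do differ from each other beyond the scatter. Nothing shown bears on what lies behind these numbers.

Still open, as far as these compounds go, is how a methoxy group or an amine would read on this phenyl ring in place of the hydroxy. From the compounds shown here alone, it is also open whether a single chlorine would behave like the pair.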